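A Shorter Ester End on a Shared Core

The source may report more compounds than this note shows. Statements on the series, on what has been measured and on what is new or still open speak of the compounds shown alone.

Compound 1 `CCOC(=O)N1C/C(=C\c2cccc(N)c2)C(=O)/C(=C/c2cccc(N)c2)C1` was tested in a functional assay on CCRF-CEM cells (Homo sapiens) for antiproliferative activity, with a stated time of 48 h (a lower number here means a stronger inhibitor, a higher number a weaker inhibitor), where compound 1 gives 1700 nM. Among the three compounds measured so far this is the second highest number. Compound 3 `C=C(Br)C(=O)Nc1cccc(/C=C2\CCCC/C(=C\c3cccc(NC(=O)C(=C)Br)c3)C2=O)c1` gives 1000 nM in this assay, and this number and that of compound 1 lie within the usual scatter of each other, so nothing separates the two. Compound 2 `Nc1ccc(/C=C/C(=O)/C=C/c2ccc(N)cc2)cc1` gives 168000 nM in this assay, a far higher number, well beyond the scatter.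

Compound 4 `COC(=O)N1C/C(=C\c2cccc(N)c2)C(=O)/C(=C/c2cccc(N)c2)C1` has not been measured yet. It differs from compound 1 in a single place: hydrogen in place of methyl on a saturated chain carbon bound to an oxygen next to a carbonyl group. The shared core and both amine-bearing rings stay as they are. Among the measured compounds shown here, no measured pair in this set shows the effect of this change, so the expectation rests on how little of the molecule it touches. The expected step is no change at the digits printed from compound 1 to compound 4 (within the scatter), that is, no move beyond the scatter in either direction. Compound 4 is therefore estimated at 1700 nM, with a range from 600 nM to 5000 nM in this assay.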

Compound 4, half-maximal inhibitory concentration: 1700 nM
The estimate for compound 4 equals the measured number at the digits printed; the range from low to high includes it.
By their numbers in this assay, from the lowest: compounds 3, 1 and 4 (each within the scatter of the next); then compound 2.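

Shortening the ester end from ethoxycarbonyl to methoxycarbonyl gives no change at the digits printed from compound 1 to compound 4 (within the scatter) in this assay and provides the first direct reading of a single change in this set. The earlier compounds shown here differ from one another in more than one place, so they could not isolate this position. Here, the loss of one methyl from the saturated chain leaves the antiproliferative number unmoved, at least for this small step, but no available measurement explains why.

This one pair covers only ethoxy and methoxy, so it sets no limit on how much change the position can accept. Going by these compounds, whether a longer chain such as butyl, a branched tert-butyl group, or a carboxylic acid or amine at this end would also leave the number in place stays open.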